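The compounds below may be only part of what the source reports. "The series", "measured", "known", "first", "only" and "open" are said of these compounds alone.

Three ureas have been run in an ADME assay on the whole organism with Oryza sativa as the target, tested at 1 uM; a lower number here means a stronger effect, a higher number a weaker effect of the compound at the concentration tested. Compound 1 `Cc1ccccc1NC(=O)N[C@@H](C)c1ccccc1` gives 99%, compound 2 `CCc1cccc(NC(=O)N[C@H](C)c2ccccc2)c1` gives 71%, and compound 3 `CCc1cccc(NC(=O)N[C@@H](C)c2ccccc2)c1` gives 94%. Compound 2 thus stands lowest of the three numbers; its nearest neighbour is compound 3 and its furthest is compound 1. Among the compounds with values here, the only step between compounds that differ in a single place is a number 23 percentage points higher from compound 2 to compound 3 (beyond the scatter), and it rests on (the fact that compounds 2 and 3 differ only in the configuration as drawn). Within the data shown here, compound 1 differs from compound 2 in more than one place, so no single step can be drawn between them.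

The account now turns to compound 4 `C[C@@H](NC(=O)Nc1cccc(C(F)(F)F)c1)c1ccccc1`, which keeps the configuration of compound 2 and alters only the aromatic substituent: trifluoromethyl in place of ethyl on an aromatic carbon. Among the measured compounds shown here, none of the measured steps bears on this change, since the one step in hand concerns configuration alone and no measured compound carries a trifluoromethyl. There is therefore no measured basis for a step in this assay in either direction, and the expectation is a number close to that of compound 2 with a wide range. The step is expected to be a number 3 percentage points lower from compound 2 to compound 4 (within the scatter). Compound 4 is accordingly estimated at 68%, with a range from 42% to 94%.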

Compound 4, a percentage reported as activity, at one concentration (the size of the read-out at that concentration, not a potency): 72%
Compound 4: middle estimate off by 4 percentage points, on the low side, and the stated range covers the measured number.
By their numbers in this assay, from the lowest: compounds 2 and 4 (each within the scatter of the next); then compounds 3 and 1 (each within the scatter of the next).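

In this assay, trifluoromethyl in place of ethyl on an aromatic carbon comes out as a number 1 percentage points higher from compound 2 to compound 4 (within the scatter), so at this position the exchange of a two-carbon chain for a group of one carbon and three fluorines produces no change that can be read. Within the data shown here, this is the first step read at the aromatic substituent, since the earlier step concerned configuration alone, and the configuration of compound 2 is held fixed in this one. Nothing at hand bears on what lies behind this result.

The compounds shown leave open how an amine, a carboxylic acid or a longer chain such as butyl would read on this aromatic carbon, and whether any group there would move the number beyond the scatter. They also leave open whether, with trifluoromethyl in place, the opposite configuration would repeat the difference seen with ethyl, which stands as a number 23 percentage points higher from compound 2 to compound 3 (beyond the scatter).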